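The source may report more compounds than this note shows. Statements on the series, on what has been measured and on what is new or still open speak of the compounds shown alone.

Measured in a functional assay on MIA PaCa-2 cells (Homo sapiens) for inhibition, read by MTT assay, with a stated time of 72 h; a lower number here means a stronger inhibitor, a higher number a weaker inhibitor:
Compound 1 `COc1cc(NC(C)CCCNC(=O)Nc2cccc(Cl)c2)c2ncccc2c1`: 21000 nM
Compound 2 `COc1cc(NC(C)CCCNC(=O)NNC(=O)Nc2cccc(F)c2)c2ncccc2c1`: 69000 nM
Compound 3 `COc1cc(NC(C)CCCNC(=O)NNC(=O)Nc2cccc(C(F)(F)F)c2)c2ncccc2c1`: 5600 nM

Compound 3, at 5600 nM, gives the lowest of the three numbers, and its gaps to both other compounds are beyond the scatter. Compound 4 `COc1cc(NC(C)CCCNC(=O)NNC(=O)Nc2ccc(O)cc2)c2ncccc2c1` keeps everything but the aryl group: 4-hydroxyphenyl in place of 3-(trifluoromethyl)phenyl on an amide-type nitrogen. The 4-hydroxyphenyl thus replaces 3-(trifluoromethyl)phenyl on an amide-type nitrogen whose other neighbour is a carbonyl carbon.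

The step nearest to this one is a 12-fold lower number from compound 2 to compound 3 (1.09 log units; beyond the scatter), a large step from trifluoromethyl in place of fluoro on an aromatic carbon. It shows that one group on that ring can move the number a long way. The modest 3.3-fold higher number from compound 1 to compound 2 (0.52 log units; beyond the scatter) changes a different stretch of the molecule and bears less. Like compound 2 at 69000 nM, compound 4 carries no trifluoromethyl group, so a higher number than that of compound 3 is expected. Among the compounds with values here, no measured compound has a 4-hydroxyphenyl group, so the size stays uncertain. The expected step is a 4.5-fold higher number from compound 3 to compound 4 (0.65 log units; beyond the scatter), beyond the scatter but smaller than the step to the fluoro compound. For compound 4 the estimated value is 25000 nM, with an expected range from 9000 nM to 70000 nM.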

Compound 4, half-maximal inhibitory concentration: 142000 nM
Compound 4: the middle estimate sits 5.7-fold (0.75 log units) below what was measured, and the stated range ends below it.
By their numbers in this assay, from the lowest: compound 3; then compound 1; then compound 2; then compound 4.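

In this assay, the aryl group on this amide-type nitrogen proves able to move the number upward as well as downward: 4-hydroxyphenyl in place of 3-(trifluoromethyl)phenyl gives a 25-fold higher number from compound 3 to compound 4 (1.40 log units; beyond the scatter), the largest step among the compounds shown. The change is not only the loss of trifluoromethyl, as the 4-hydroxyphenyl group also stands apart from 3-fluorophenyl, with a 2.1-fold higher number from compound 2 to compound 4 (0.31 log units; beyond the scatter), making compound 4 the weakest of the four. The step of a 6.8-fold higher number from compound 1 to compound 4 (0.83 log units; beyond the scatter) replaces a longer stretch of the molecule, so it says less about the aryl group alone.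

No measured evidence accounts for these differences. From the compounds shown here alone, whether the higher number belongs to the hydroxyl group or to its place on the ring stays open, as does how an aryl group bearing an amine or a carboxylic acid would compare.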